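Trimming the oxime side chain of compound 1

This account rests on a few compounds, and the source may have more. Where it says the series, first, only, none or still open, it means among the compounds named here.

Compound 1 `C/C(=N\OCCSc1nnc(C)s1)c1ccc(Sc2cc(F)cc(C3CCOCC3)c2)cc1` was tested in a functional assay (blood) for inhibition, with Homo sapiens as the target (a higher number here means a weaker inhibitor, a lower number a stronger inhibitor), where compound 1 gives 230 nM, the highest of the three numbers at hand. Compound 3 `CCOC(=O)/C(=N\O)c1ccc(Sc2cc(F)cc(C3CCOCC3)c2)cc1` gives 170 nM, within the scatter of compound 1. Compound 2 `CO[C@]1(c2cc(F)cc(S(=O)(=O)c3ccc(/C(C)=N/OCC#N)cc3)c2)CCO[C@@H](C)C1` gives 60 nM, beyond the scatter from compound 1. Compound 4 `CC(=O)O/N=C(\C)c1ccc(Sc2cc(F)cc(C3CCOCC3)c2)cc1` has not yet been measured; it differs from compound 1 in one place: acetyl in place of 2-((5-methyl-1,3,4-thiadiazol-2-yl)sulfanyl)ethyl on an oxygen. Among the measured compounds shown here, no measured pair shows the effect of such a change, and the three compounds share no single-point comparison. The step from compound 1 is expected to be small, with no clear direction beyond the scatter, so the estimated step is a 1.1-fold higher number from compound 1 to compound 4 (0.04 log units; within the scatter). Compound 4 is therefore expected to give about 250 nM, between 80 nM and 800 nM.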

Compound 4, half-maximal inhibitory concentration: 50 nM
Beside the measured number, compound 4's estimate is 5.0-fold (0.70 log units) above it; measured number outside the range, below it.
By their numbers in this assay, from the lowest: compounds 4 and 2 (each within the scatter of the next); then compounds 3 and 1 (each within the scatter of the next).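

On the oxygen bound to the double-bonded nitrogen, the 2-((5-methyl-1,3,4-thiadiazol-2-yl)sulfanyl)ethyl group is not needed: in this assay, acetyl in its place gives a 4.6-fold lower number from compound 1 to compound 4 (0.66 log units; beyond the scatter), so this position accepts a group of far fewer heavy atoms with a stronger result. Exchanging the group of 8 heavy atoms on the aromatic carbon for the group of 7 gives a 3.4-fold lower number from compound 3 to compound 4 (0.53 log units; beyond the scatter), the same direction. No measurement here explains either step. On these data alone, whether a plain methyl or a longer propanoyl on that oxygen would hold this strength stays open.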